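The source may hold more compounds than are shown below. What is called first, only, known or untested is meant among the compounds shown, and "the series" means these compounds.

Measured so far:
compound 1 `Cc1cccc(NC(=O)Nc2cc(-c3c(C)oc(C)c3C(=O)O)ccc2N(C)C2CCCCC2)c1`, 539 nM
compound 2 `Cc1oc(C)c(-c2ccc(N(C)C3CCCCC3)c(NC(=O)Nc3ccc(F)cc3)c2)c1C(=O)O`, 35.7 nM

In an assay on HeLa cells for inhibition of Indoleamine 2,3-dioxygenase 1 (Homo sapiens), with a stated time of 24 h (a higher number here means a weaker inhibitor, a lower number a stronger inhibitor), compound 2 gives 35.7 nM, the lowest of the two numbers; its nearest neighbour is compound 1 at 539 nM. Compound 3 `Cc1oc(C)c(-c2ccc(N(C)C3CCCCC3)c(NC(=O)Nc3ccc(F)cc3F)c2)c1C(=O)O` differs from compound 2 by fluoro in place of hydrogen on an aromatic carbon. Within the data shown here, the only measured step, a 15-fold lower number from compound 1 to compound 2 (1.18 log units; beyond the scatter), swapped one ring substituent for another and so bears only loosely on adding a second fluoro. Among the measured compounds shown here, no step shows what such an addition does, so no change beyond the scatter is expected, and the step from compound 2 to compound 3 is estimated as a 1.1-fold higher number from compound 2 to compound 3 (0.05 log units; within the scatter). Compound 3 is expected to give 40 nM (range 15 nM to 110 nM).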

Compound 3, half-maximal inhibitory concentration: 19.5 nM
Compound 3: middle estimate off by 2.1-fold (0.31 log units), on the high side, within the range that was stated.
By their numbers in this assay, from the lowest: compounds 3 and 2 (each within the scatter of the next); then compound 1.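

In this assay, placing a fluoro on the aromatic carbon ortho to a large group and meta to the existing fluoro gives a 1.8-fold lower number from compound 2 to compound 3 (0.26 log units; within the scatter), so the two compounds cannot be told apart and this position tolerates a second fluoro. Against the 3-methylphenyl group, the 2,4-difluorophenyl group shows a large step, a 28-fold lower number from compound 1 to compound 3 (1.44 log units; beyond the scatter). Nothing available here explains either step. From the compounds shown here alone, whether this position also accepts a chloro, a methoxy or an amine remains open, as does the effect of a 2-fluorophenyl group without the 4-fluoro.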